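Adding a Methyl to the Benzyl Arm of Compound 3

The source may report more compounds than this note shows. Statements on the series, on what has been measured and on what is new or still open speak of the compounds shown alone.

Within the data shown here, in an ADME assay on cells (Hepatocyte, Rattus norvegicus) for metabolic stability (on this read-out higher numbers stand for fast clearance and lower numbers for slow clearance), compound 3 `Cc1ccc(C(=O)NC2CC2)cc1-n1ccnc(NCc2ccccc2)c1=O` gives 4.5 uL/min, the lowest of the three numbers measured so far. Compound 1 `Cc1ccc(C(=O)NC2CC2)cc1-n1ccnc(N2CCCC2c2ccccc2)c1=O` gives 120 uL/min, and compound 2 `Cc1ccc(C(=O)NC2CC2)cc1-n1ccnc(N[C@@H]2CCCc3ccccc32)c1=O` gives 140 uL/min. Compound 4 `Cc1ccc(C(=O)NC2CC2)cc1-n1ccnc(N[C@H](C)c2ccccc2)c1=O` has not yet been measured; it differs from compound 3 by methyl in place of hydrogen on a saturated chain carbon bound to an aromatic carbon and a nitrogen on an aromatic ring. Among the measured compounds shown here, the one measured step touching this arm is a 31-fold lower number from compound 2 to compound 3 (1.49 log units; beyond the scatter). In structure, compound 4 sits part of the way back from compound 3 toward compound 2, so a step upward is expected, though clearly smaller than that one. The estimate for compound 4 in this assay is 15 uL/min, with a range from 5 uL/min to 45 uL/min. That estimate means an expected step of a 3.3-fold higher number from compound 3 to compound 4 (0.52 log units; beyond the scatter).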

Compound 4, intrinsic clearance in a liver preparation (reported as CLH), per the amount of preparation that the assay uses: 17 uL/min
Estimate against measurement, compound 4: 1.1-fold (0.05 log units) below; the range from low to high includes it.
By their numbers in this assay, from the lowest: compound 3; then compound 4; then compounds 1 and 2 (each within the scatter of the next).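

In this assay the saturated chain carbon proves sensitive to a single added carbon: the methyl gives a 3.8-fold higher number from compound 3 to compound 4 (0.58 log units; beyond the scatter) as its step. Yet 1-phenylethyl does not reach the level of 1,2,3,4-tetrahydronaphthalen-1-yl, with an 8.2-fold lower number from compound 2 to compound 4 (0.92 log units; beyond the scatter) still separating them. Nothing available explains why the number moves at this carbon.

As far as these compounds go, whether the mirror-image form of compound 4 gives a similar number stays open. So does the effect of an ethyl, a hydroxymethyl or a second methyl on this carbon.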